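The source may hold more compounds than are shown below. What is called first, only, known or untested is meant among the compounds shown, and "the series" means these compounds.

Of the compounds shown here, two have been tested so far in a functional assay on HO8910 cells (Homo sapiens) for inhibition, read by MTT assay, with a stated time of 24 h, tested at 1 ug/mL; a lower number here means less inhibition of growth, a higher number more inhibition of growth at the concentration tested. Compound 1 `O=C(CCCCC1CCSS1)Nc1ccccc1Cl` gives 7.74%, and compound 2 `O=C(CCCCC1CCSS1)Nc1ccc(OC(F)(F)F)cc1` gives 10%. These two values lie within the usual scatter of each other, so the data do not separate compound 2 from compound 1.

Compound 3 `O=C(CCCCC(S)CCS)Nc1ccc(OC(F)(F)F)cc1` keeps the rest of compound 2 but opens its ring: a group of 5 heavy atoms (3 carbon, 2 sulfur; no ring) in place of a group of 5 heavy atoms (3 carbon, 2 sulfur; one five-membered non-aromatic ring with 2 hetero atoms), on a saturated chain carbon, four bonds along the chain from a carbonyl carbon. A 1,3-disulfanylpropyl group, which has no ring, replaces the five-membered non-aromatic ring, on a saturated chain carbon, four bonds along the chain from a carbonyl carbon. The atoms kept are the same kinds, but the new group carries hydrogen-bond donors that the ring lacks.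

Going by the values given here, no two tested compounds differ in only one place, so no measured step can serve as a guide for this change. The expectation in this assay is therefore a small rise at most, with no change beyond the scatter as the likeliest outcome. The estimated step is a number 2 percentage points higher from compound 2 to compound 3 (within the scatter). For compound 3 the expected value is 12%, with an estimated range from 3% to 25%.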

Compound 3, percent growth inhibition at one concentration: 0.56%
Compound 3: middle estimate off by 11.4 percentage points, on the high side, outside the stated range (below it).
By their numbers in this assay, from the lowest: compounds 3, 1 and 2 (each within the scatter of the next).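

Going by these compounds alone, this is the first pair in this assay that differs in only one place, so it gives the first direct reading of a change on a saturated chain carbon, four bonds along the chain from a carbonyl carbon: replacing the five-membered ring with a 1,3-disulfanylpropyl group gives a number 9.4 percentage points lower from compound 2 to compound 3 (within the scatter). In this assay, therefore, the open group, with its hydrogen-bond donors, cannot be told apart from the ring, so this single step shows neither that the intact ring matters at this position nor that the added donors do. Nothing available offers an explanation for this result.

The compounds shown leave open whether another group at this position, such as a carboxylic acid, an amine or a longer chain, would move the reading beyond the usual scatter from compound 2. They also leave open whether the same ring opening would give a similar result on compound 1, and whether a real difference between compound 2 and compound 3 would appear at a higher test concentration.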